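Exchanging the side chain of compound 3

The source may report more compounds than this note shows. Statements on the series, on what has been measured and on what is new or still open speak of the compounds shown alone.

Measured in a functional assay on A549 cells (Homo sapiens) for antiproliferative activity, read by sulforhodamine B assay, with a stated time of 72 h; a lower number here means a stronger inhibitor, a higher number a weaker inhibitor:
- compound 1 `CCCCS(=O)(=O)Nc1cc(-c2ccc3ncnc(NCCN(C)C)c3c2)cnc1OC`: 1320 nM
- compound 2 `COc1ncc(-c2ccc3ncnc(NCCN(C)C)c3c2)cc1NS(=O)(=O)c1ccc(F)cc1`: 2420 nM
- compound 3 `COc1ncc(-c2ccc3ncnc(NCc4ccncc4)c3c2)cc1NS(=O)(=O)c1ccc(F)cc1F`: 11400 nM

Compound 3 has the highest number of the three, beyond the scatter from both others. Compound 4 `COc1ncc(-c2ccc3ncnc(NCCN(C)C)c3c2)cc1NS(=O)(=O)c1ccc(F)cc1F` carries (dimethylamino)methyl in place of pyridin-4-yl on a saturated chain carbon bound to a nitrogen on an aromatic ring. Within the data shown here, no measured step covers this exchange. The only one, a 1.8-fold higher number from compound 1 to compound 2 (0.26 log units; within the scatter), concerns a group on a sulfonyl sulfur and stays within the scatter. The resulting 2-(dimethylamino)ethyl is shared with compound 1 at 1320 nM and compound 2 at 2420 nM, so a lower number, beyond the scatter, is expected. The step expected in this assay is a 5.2-fold lower number from compound 3 to compound 4 (0.71 log units; beyond the scatter). The estimated value for compound 4 is 2200 nM, with an expected range of 800 nM to 6000 nM.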

Compound 4, half-maximal inhibitory concentration: 940 nM
Compound 4: the middle estimate sits 2.3-fold (0.37 log units) above what was measured; the range from low to high includes it.
By their numbers in this assay, from the lowest: compounds 4, 1 and 2 (each within the scatter of the next, the first and the last beyond it); then compound 3.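

In this assay the side chain now has a direct reading: 2-(dimethylamino)ethyl in place of (pyridin-4-yl)methyl gives a 12-fold lower number from compound 3 to compound 4 (1.08 log units; beyond the scatter) and is the change that counts most here. Fluoro in place of hydrogen on an aromatic carbon gives a 2.6-fold lower number from compound 2 to compound 4 (0.41 log units; beyond the scatter) as a modest step, and 2,4-difluorophenyl in place of butyl on the sulfonyl sulfur gives a 1.4-fold lower number from compound 1 to compound 4 (0.15 log units; within the scatter) within the scatter. No evidence bearing on the cause of these steps is available.

Open, on these data alone, is whether a morpholine or piperidine at the chain end, or a longer chain, would hold this level. Also open, as far as these compounds go, is whether pyridin-4-yl costs as much with butyl on the sulfonyl sulfur.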